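Swapping the Acid Group of a Fatty Acid Receptor Agonist

This account rests on a few compounds, and the source may have more. Where it says the series, first, only, none or still open, it means among the compounds named here.

Compound 1 `Cc1nc(-c2ccc(C(F)(F)F)cc2)sc1CNc1ccc(OCC(=O)O)cc1` is the stronger of two agonists measured in a functional assay on CHO cells for agonist activity at Free fatty acid receptor 1 (Homo sapiens), read by a luciferase reporter; on this read-out lower numbers stand for smaller maximal responses and higher numbers for larger maximal responses: compound 1 reaches 100%, while compound 2 `CC(CC(=O)O)c1ccc(NCc2cccc(Oc3ccccc3)c2)cc1` reaches 83%, a gap beyond the usual scatter. Compound 3 `Cc1nc(-c2ccc(C(F)(F)F)cc2)sc1CNc1ccc([C@H]2C[C@@H]2C(=O)NC2CCNC2)cc1` keeps the core of compound 1 but carries a different group on the aromatic carbon: 2-((pyrrolidin-3-yl)carbamoyl)cyclopropyl in place of carboxymethoxy on an aromatic carbon. Within the data shown here, no measured pair shows the effect of such an exchange, so the expectation rests on compound 1 alone. A drop in maximal response is expected, a number 30 percentage points lower from compound 1 to compound 3 (beyond the scatter). Compound 3 is estimated to reach 70%, within 30% to 100%.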

Compound 3, largest response reached (reported as percent of maximum), in percent of the reference or control that the assay uses: 52%
The estimate for compound 3 lay 18 percentage points above the measured number; low and high end bracket the measured number.
By their numbers in this assay, from the lowest: compound 3; then compound 2; then compound 1.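

In this assay the group on this aromatic carbon clearly matters: 2-((pyrrolidin-3-yl)carbamoyl)cyclopropyl in place of carboxymethoxy gives a number 48 percentage points lower from compound 1 to compound 3 (beyond the scatter) and so a large loss. Even so, compound 3 still reaches 52% with no carboxylic acid at this place. No data shown here explain the drop.

On these data alone, the step changes two things at once, so it stays open whether the loss follows from removing the carboxylic acid or from adding the pyrrolidine amide. A 2-carboxycyclopropyl group on the same carbon would help separate the two.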